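The source may hold more compounds than are shown below. What is called first, only, known or untested is meant among the compounds shown, and "the series" means these compounds.

Two compounds have numbers so far in an ADME assay on MT4 cells (Homo sapiens) for cytotoxicity, read by MTT assay (a higher number here means that more compound is tolerated, a lower number that less compound is tolerated), so far as the record goes:

- compound 1 `O=C1c2ccccc2C(=O)N1CCOC(=S)N(C(=O)c1c(Cl)cccc1Cl)c1ccc(Cl)cc1` gives 20000 nM
- compound 2 `COc1cccc(OC)c1C(=O)N(C(=S)OCCN1C(=O)c2ccccc2C1=O)c1ccc(Cl)cc1` gives 69000 nM

Compound 2 at 69000 nM is the higher of the two, so it is the better tolerated, and compound 1 lies beyond the scatter beneath it. Going by the values given here, the next compound, compound 3 `Cc1cc(C(=O)N(C(=S)OCCN2C(=O)c3ccccc3C2=O)c2ccc(Cl)cc2)ccc1Br`, keeps the shared core and changes only one group (4-bromo-3-methylphenyl in place of 2,6-dimethoxyphenyl on a carbonyl carbon). In words, 4-bromo-3-methylphenyl takes the place of 2,6-dimethoxyphenyl on a carbonyl carbon.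

One measured step changes the same place: a 3.5-fold higher number from compound 1 to compound 2 (0.54 log units; beyond the scatter) was modest. Neither of its groups is the one entering, so it offers a size more than a firm direction. The entering group carries a halogen, as the 2,6-dichlorophenyl of compound 1 (20000 nM) does, and it has no methoxy, so a modest move down is expected. The estimated step of a 2.3-fold lower number from compound 2 to compound 3 (0.36 log units; beyond the scatter) is of similar size to the measured one. Compound 3 is expected at 30000 nM (estimated range 10000 nM to 90000 nM).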

Compound 3, half-maximal cytotoxic concentration: 18000 nM
Estimate against measurement, compound 3: 1.7-fold (0.22 log units) above; the measured number falls inside the stated range.
By their numbers in this assay, from the lowest: compounds 3 and 1 (each within the scatter of the next); then compound 2.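

In this assay, the group on the carbonyl carbon has now been changed twice, and putting 4-bromo-3-methylphenyl in place of 2,6-dimethoxyphenyl gives a 3.8-fold lower number from compound 2 to compound 3 (0.58 log units; beyond the scatter). This step is close in size to the earlier one, a 3.5-fold higher number from compound 1 to compound 2 (0.54 log units; beyond the scatter), but it runs the other way, so the higher number seen with 2,6-dimethoxyphenyl does not carry over to the new group. Replacing 2,6-dichlorophenyl with 4-bromo-3-methylphenyl gives a 1.1-fold lower number from compound 1 to compound 3 (0.05 log units; within the scatter), so the two halogen-bearing groups cannot be told apart here despite their different substituents, and among these three compounds only the one with two methoxy groups stands apart.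

No measured information is available to explain these differences.

Going by these compounds, it remains open whether the higher number belongs to the methoxy groups themselves or simply goes with having no halogen, a question that a plain phenyl or a phenyl carrying a single methoxy group at this place could help to settle. On these data alone, how a ring bearing an amine or a carboxylic acid would behave here also remains unknown.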